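The compounds below may be only part of what the source reports. "The series", "measured", "known", "first", "only" and "open" are said of these compounds alone.

Compound 1 `CC(C)c1cccc(C(C)C)c1NC(=O)NC1CCCc2ccccc21` gives 850 nM in an assay on microsomes from intestine for inhibition of acyl-CoA:cholesterol acyltransferase (Oryctolagus cuniculus); on this read-out lower numbers stand for stronger inhibition and higher numbers for weaker inhibition.
Compound 2 `COc1ccccc1NC(=O)NCC1(c2ccccc2)CCCCC1` gives 270 nM.
Compound 3 `CC(C)c1ccccc1NC(=O)NCC1(c2ccccc2)CCCCC1` gives 390 nM.

Compound 2 has the lowest of the three numbers. For the measured compounds named here, compound 3 stands nearest to it, and the only single-change step measured so far, a 1.4-fold higher number from compound 2 to compound 3 (0.16 log units; within the scatter), exchanges methoxy for isopropyl on an aromatic carbon and stays within the scatter, so these two cannot be ranked. Compound 1 lies furthest from compound 2, beyond the scatter.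

Compound 4 `COc1ccc(NC(=O)NCC2(c3ccccc3)CCCCC2)cc1` differs from compound 2 by 4-methoxyphenyl in place of 2-methoxyphenyl on an amide-type nitrogen; the two have the same atoms, joined differently. Going by the values given here, no measured step changes where a group sits on this ring, so the measured steps give no direct guide to this change; the one step known touches only what the group is, not where it stands.

With that gap in the data, compound 4 is expected to show a step of a 3.0-fold higher number from compound 2 to compound 4 (0.47 log units; beyond the scatter), toward a higher number, though a result within the scatter cannot be excluded. Compound 4 is therefore estimated at 800 nM, in a range from 250 nM to 3000 nM.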

Compound 4, half-maximal inhibitory concentration: 4900 nM
For compound 4 the middle estimate is 6.1-fold (0.79 log units) below the measured one; measured number above the stated range.
By their numbers in this assay, from the lowest: compounds 2 and 3 (each within the scatter of the next); then compound 1; then compound 4.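

For the compounds shown here, until this point, the only measured single change on this ring replaced one group with another, leaving the effect of the group's place untested. Compound 2 and compound 4 have the same atoms, joined differently, yet 4-methoxyphenyl in place of 2-methoxyphenyl on the amide-type nitrogen gives an 18-fold higher number from compound 2 to compound 4 (1.26 log units; beyond the scatter) in this assay, a large step showing that, for this pair, where the methoxy group stands matters a great deal. Nothing available here explains why the number rises so far.

Going by these compounds, whether the isopropyl group of compound 3 would respond in the same way to such a move remains open. On these data alone, it is also open whether fluorine or an amine, carried in the same place as the methoxy group of compound 4, would give a lower or a higher number.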